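The source may hold more compounds than are shown below. What is called first, only, known or untested is meant among the compounds shown, and "the series" means these compounds.

Working notes on the triamine series. Compound 1 `CNCCCNCCCNC` gives 4800 nM in a functional assay on L1210 cells (Mus musculus) for inhibition, with a stated time of 96 h (on this read-out lower numbers stand for stronger inhibition and higher numbers for weaker inhibition), the lowest of the three numbers measured. Compound 2 `CCNCCCNCCCNCC` gives 10000 nM in this assay, a gap to compound 1 just beyond the scatter. Compound 3 `CCCNCCCNCCCN` gives 100000 nM in this assay, far weaker than either. Within the data shown here, no step between two measured compounds differing in one place is available, so nothing here calibrates a single change.

Compound 4 `CNCCCCNCCCNC` has not been measured. It differs from compound 1 as follows: (methylamino)methyl in place of methylamino on a saturated chain carbon, three bonds along the chain from an amine nitrogen. Among the measured compounds shown here, with no comparable step in the data, the change is expected to cost little, a step from compound 1 of a 1.7-fold higher number from compound 1 to compound 4 (0.22 log units; within the scatter) in this assay, within or only slightly beyond the scatter. Compound 4 is estimated at 8000 nM, range 2500 nM to 25000 nM.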

Compound 4, half-maximal inhibitory concentration: 1700 nM
Compound 4: the middle estimate sits 4.7-fold (0.67 log units) above what was measured; measured number outside the range, below it.
By their numbers in this assay, from the lowest: compound 4; then compound 1; then compound 2; then compound 3.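

Placing (methylamino)methyl in place of methylamino on a saturated chain carbon, three bonds along the chain from an amine nitrogen, gives a 2.8-fold lower number from compound 1 to compound 4 (0.45 log units; beyond the scatter) in this assay. This position therefore accepts the change with a modest gain rather than a cost, and the series now has its first calibrated single-place step. Nothing available accounts for the gain.

As far as these compounds go, whether a longer chain, such as 2-(methylamino)ethyl, would extend or reverse this step remains open. So does the effect of a primary amine or an ethylamino group at this position.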